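Amide side chain: cyclohexyl versus aryl-containing groups

A few compounds are considered here, and "the series" means these few. Any claim that something is new, unique, unknown or untested is made for them only; others in the source may bear on it.

For the measured compounds named here, compound 2 `CC(C)C[C@H](N)c1cc(C(F)(F)F)ccc1N1CCN(C(=O)CCC2CCCCC2)CC1` gives 5700 nM in an assay on HEK293 cells for displacement of a labelled ligand from Melanocortin receptor 4 (Homo sapiens) (a lower number here means a stronger inhibitor, a higher number a weaker inhibitor), the highest of the two numbers measured so far; its nearest neighbour is compound 1 `CC(C)C[C@H](N)c1cc(C(F)(F)F)ccc1N1CCN(C(=O)[C@H](C)Cc2ccc(Cl)cc2)CC1`, which gives 31 nM. The step of a 180-fold higher number from compound 1 to compound 2 (2.26 log units; beyond the scatter) is the only one that bears on the next change. Compound 3 `CC(C)C[C@H](N)c1cc(C(F)(F)F)ccc1N1CCN(C(=O)COc2cccc3ccccc23)CC1` differs from compound 2 by (naphthalen-1-yl)oxy in place of cyclohexylmethyl on a saturated chain carbon bound to a carbonyl carbon. As this change restores aromatic rings to the side chain, a large decrease in this assay is expected, by roughly a 38-fold lower number from compound 2 to compound 3 (1.58 log units; beyond the scatter). Compound 3 is therefore estimated at 150 nM, with a range of 30 nM to 1500 nM.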

Compound 3, inhibition constant: 2600 nM
Estimate against measurement, compound 3: 17-fold (1.24 log units) below; the whole stated range lies below it.
By their numbers in this assay, from the lowest: compound 1; then compound 3; then compound 2.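

In this assay, aromatic rings on this side chain do not by themselves bring back the strength of compound 1: (naphthalen-1-yl)oxy in place of cyclohexylmethyl gives only a modest gain (a 2.2-fold lower number from compound 2 to compound 3 (0.34 log units; beyond the scatter)). Most of the gap remains, since ((naphthalen-1-yl)oxy)methyl falls well short of 1-(4-chlorobenzyl)ethyl (an 84-fold higher number from compound 1 to compound 3 (1.92 log units; beyond the scatter)). No supporting data explain this difference.

Open, going by these compounds, is whether 4-chlorophenoxy on the saturated chain carbon bound to a carbonyl carbon would come closer to compound 1. The compounds shown also do not separate the contributions of the chlorine and the branching methyl in 1-(4-chlorobenzyl)ethyl.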